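The compounds below may be only part of what the source reports. "The series", "measured", "known", "first", "only" and "open" are said of these compounds alone.

Measured so far in an in vitro functional assay on 1321-N1 cells for agonist activity at P2Y purinoceptor 6 (Homo sapiens), read by scintillation proximity assay and inositol phosphate accumulation; a higher number here means that more compound is needed for the effect, a lower number that less compound is needed:
Compound 1 `Nc1nc(=O)ccn1[C@@H]1O[C@H](COP(=O)(O)O)[C@@H](O)[C@H]1O` gives > 100000 nM.
Compound 3 `CSc1nc(=O)ccn1[C@@H]1O[C@H](COP(=O)(O)O)[C@@H](O)[C@H]1O` gives > 100000 nM.
Compound 2 `CCCSc1nc(=O)ccn1[C@@H]1O[C@H](COP(=O)(O)OP(=O)(O)O)[C@@H](O)[C@H]1O` gives >= 100000 nM.

Each of these values is a limit of the assay rather than a number. Compound 3 stands at the limit of > 100000 nM in this assay, at which 2 of the 3 values shown sit, the same limit at which compound 1 sits. Compound 2, which carries both a propylsulfanyl group and a diphosphate, sits at the limit of >= 100000 nM in this assay, at which 1 of the 3 values shown sits. Going by the values given here, the only single-point step among the measured compounds is a step that the two limits leave unreadable from compound 1 to compound 3, and its size cannot be read, as both of its ends are limits.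

Compound 4 `CCCSc1nc(=O)ccn1[C@@H]1O[C@H](COP(=O)(O)O)[C@@H](O)[C@H]1O` differs from compound 3 by ethyl in place of hydrogen on a saturated chain carbon bound to a sulfur. Among the compounds with values here, the one measured step that touches the sulfur-bound group cannot be sized, and compound 2, which also carries the propylsulfanyl group, returns no number. Within the data shown here, nothing among the measured compounds points to a direction in this assay. Compound 4 is therefore expected to stay at the limit, and the step that the limit leaves unreadable from compound 3 to compound 4 is expected to be no more than a formal one. The estimate for compound 4 is 150000 nM, with a range from 30000 nM to 1000000 nM.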

Compound 4, half-maximal effective concentration: 6200 nM
Beside the measured number, compound 4's estimate is 24-fold (1.38 log units) above it; measured number below the stated range.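

In this assay, the sulfur-bound chain turns out to matter at this position: going from methyl to propyl gives an at least 16-fold lower number from compound 3 to compound 4 (1.20 log units; beyond the scatter), and the propylsulfanyl group in place of amino gives an at least 16-fold lower number from compound 1 to compound 4 (1.20 log units; beyond the scatter). With the propylsulfanyl group held fixed, the phosphate also counts, as losing the outer phosphate gives an at least 16-fold lower number from compound 2 to compound 4 (1.20 log units; beyond the scatter). All three steps start from a limit of the assay rather than a number, and for compound 3 that reads: the limit of > 100000 nM in this assay, at which 2 of the 4 values shown sit.

The step from amino to methylsulfanyl cannot be read, so the shortest sulfur-bound group shown has no measured effect. From the compounds shown here alone, whether a butyl chain, a longer chain or a benzyl group on the sulfur would lower the number further remains open, as does whether a triphosphate would fare differently from the monophosphate.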